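Purine acetamides in the oral tail flick test

A few compounds are considered here, and "the series" means these few. Any claim that something is new, unique, unknown or untested is made for them only; others in the source may bear on it.

Three compounds have been measured in a functional assay on the whole organism (Tail, strain ICR) with Mus musculus as the target, in the tail flick test, with a stated time of 120 min, at a dose of 25 umol/kg by the oral route; on this read-out lower numbers stand for a weaker effect and higher numbers for a stronger effect at the one dose given:

compound 1 `C[C@H](NC(=O)CN(c1nc(Cl)nc2[nH]cnc12)C1CC1)C(=O)OCc1ccccc1`: 36.1%
compound 2 `O=C(CN(c1nc(Cl)nc2[nH]cnc12)C1CC1)N[C@@H](CC(=O)OCc1ccccc1)C(=O)OCc1ccccc1`: 12.1%
compound 3 `O=C(CN(c1ncnc2c1ncn2C1CCCCO1)C1CC1)N[C@@H](CC(=O)OCc1ccccc1)C(=O)OCc1ccccc1`: 7.82%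

Compound 1 and compound 2 share one core and differ in a single place, (hydrogen in place of benzyloxycarbonyl on a saturated chain carbon, two bonds along the chain from an amide-type nitrogen and a carbonyl carbon). This change gave a number 24 percentage points higher from compound 2 to compound 1 (beyond the scatter). Compound 3 carries a different core; how its core differs from that of compound 2 is not broken down here. Compound 3 and compound 2 lie within the scatter of each other, while compound 1 stands beyond the scatter above compound 3.

Compound 4 `C[C@H](NC(=O)CN(c1ncnc2c1ncn2C1CCCCO1)C1CC1)C(=O)OCc1ccccc1` is not yet measured. It differs from compound 3 by hydrogen in place of benzyloxycarbonyl on a saturated chain carbon, two bonds along the chain from an amide-type nitrogen and a carbonyl carbon, the same change, at the same place, as that from compound 2 to compound 1. Because a number 24 percentage points higher from compound 2 to compound 1 (beyond the scatter) was seen on the other core, a step of similar size is expected here, with the reservation that the core of compound 3 has not itself been tested for this change. Compound 4 is therefore estimated at 28%, most likely between 10% and 45%. This expectation means a step of a number 20.2 percentage points higher from compound 3 to compound 4 (beyond the scatter).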

Compound 4, a percentage reported as activity, at one dose (the size of the read-out at that dose, not a potency): 25.3%
For compound 4 the middle estimate is 2.7 percentage points above the measured one; measured number inside the range.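

Replacing benzyloxycarbonyl by hydrogen gave a number 17.5 percentage points higher from compound 3 to compound 4 (beyond the scatter) in this assay. Set beside the step on the other core, the change carried over in direction, and the two sizes do not differ beyond what repeated measurements would allow: the same change on two cores in this assay, a number 24 percentage points higher (beyond the scatter) from compound 2 to compound 1 and a number 17.5 percentage points higher (beyond the scatter) from compound 3 to compound 4, 6.5 percentage points apart, within the scatter of two such steps

Within the data shown here, this agreement rests on only two cores and on one oral dose at one stated time, so it shows that the change carried between the core of compound 2 and the core of compound 3, but not that it would hold on any further core, and it gives neither a potency nor a reason for the step.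

The compounds shown leave open whether a carboxylic acid or an amine on that saturated chain carbon would give a read-out like that of compound 4. They also leave open whether a longer chain there would keep the gain that came with hydrogen.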